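Acyl sulfonamide Replacing the Cyanoamide in an Angiotensin Series

The source may hold more compounds than are shown below. What is called first, only, known or untested is meant among the compounds shown, and "the series" means these compounds.

Measured so far:
compound 1, `CC[C@H](C)[C@H](NC(=O)c1cccc(Cn2ccnc2)c1)C(=O)NNS(=O)(=O)c1ccccc1`, 6% in an assay on HEK293 cells for displacement of a labelled ligand from Type-2 angiotensin II receptor (Homo sapiens), tested at 1 uM; on this read-out lower numbers stand for a weaker effect and higher numbers for a stronger effect at the one concentration tested
compound 2, `CC[C@H](C)[C@H](NC(=O)c1cccc(Cn2ccnc2)c1)C(=O)NC#N`, 6%

Going by the values given here, compound 2 sits level with compound 1 in this assay, and the one measured step, no change at the digits printed from compound 1 to compound 2 (within the scatter), stayed within the scatter. Compound 3, `CC[C@H](C)[C@H](NC(=O)c1cccc(Cn2ccnc2)c1)C(=O)NS(=O)(=O)c1ccccc1`, is compound 2 with phenylsulfonyl in place of cyano on an amide-type nitrogen. The phenylsulfonyl group it gains is the same group that compound 1 carries one bond further out, and compound 1 was no stronger than compound 2. Among the compounds with values here, the only step that bears on it thus showed no change, so the expected step of a number 2 percentage points higher from compound 2 to compound 3 (within the scatter) is none beyond the scatter. Compound 3 is therefore estimated at 8%, within 0% to 25%.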

Compound 3, a percentage reported as inhibition, at one concentration (the size of the read-out at that concentration, not a potency): 5%
Compound 3: middle estimate off by 3 percentage points, on the high side; the measured number falls inside the stated range.
By their numbers in this assay, from the lowest: compounds 3, 1 and 2 (each within the scatter of the next).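

In this assay, placing phenylsulfonyl on the amide-type nitrogen instead of cyano gives a number 1 percentage points lower from compound 2 to compound 3 (within the scatter), and removing the amino link that holds phenylsulfonyl one bond further out gives a number 1 percentage points lower from compound 1 to compound 3 (within the scatter). Neither the aromatic ring that enters nor that link separates these compounds at the one concentration tested. Nothing available here explains these readings. On these data alone, the shared core stays the same throughout, so what it contributes remains open. As far as these compounds go, whether a carboxylic acid or an amine in this place would give a different reading also remains open.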